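The source may hold more compounds than are shown below. What is called first, only, known or untested is meant among the compounds shown, and "the series" means these compounds.

Compound 1 `COc1cc2nc([S+]([O-])CC(=O)Nc3ccc(C(F)(F)F)cc3)nc(Nc3c(C)cc(/C=C/C#N)cc3C)c2cc1OC`: 52200 nM
Compound 2 `COc1cc2nc([S+]([O-])CC(=O)Nc3ccccc3[N+](=O)[O-])nc(Nc3c(Cl)cc(/C=C/C#N)cc3Cl)c2cc1OC`: > 199000 nM

From the compounds shown here alone, in an ADME assay on MT4 cells (Homo sapiens) for cytotoxicity, read by MTT assay, with a stated time of 5 days (on this read-out lower numbers stand for higher toxicity in this test and higher numbers for lower toxicity in this test), compound 2 reaches only a limit of the test, > 199000 nM, so its exact value is unknown. Compound 1, by contrast, gives a number, 52200 nM; (the limit of > 199000 nM in this assay, at which 1 of the 2 values shown sits). Compound 3 `COc1ccccc1NC(=O)C[S+]([O-])c1nc(Nc2c(Cl)cc(/C=C/C#N)cc2Cl)c2cc(OC)c(OC)cc2n1` has not yet been measured. It differs from compound 2 in one place: methoxy in place of nitro on an aromatic carbon. Among the compounds with values here, no measured pair isolates this change, so the step from compound 2 to compound 3 is expected to be an at least 1.3-fold lower number from compound 2 to compound 3 (0.12 log units; that floor lies within the scatter), not clearly in either direction beyond the usual scatter. Compound 3 is therefore estimated at 150000 nM, expected to fall between 50000 nM and 300000 nM.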

Compound 3, half-maximal cytotoxic concentration: > 204000 nM
Compound 3: a limit, no number (the forecaster's own chance of this, stated with the estimate: 40%); middle value at least 1.3-fold (0.13 log units) away from the limit.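

In this assay compound 3 gives > 204000 nM, a limit and not a number. Within the data shown here, compound 2 also stands at a limit, so no step between compound 2 and compound 3 can be read. From the compounds shown here alone, whether methoxy and nitro differ on this read-out stays open.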